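The source may hold more compounds than are shown below. What is called first, only, known or untested is meant among the compounds shown, and "the series" means these compounds.

Measured so far in an ADME assay on Huh-7 cells (Homo sapiens) for cytotoxicity, read by MTT assay, with a stated time of 48 h; a lower number here means that less compound is tolerated, a higher number that more compound is tolerated:
- compound 1 `Nc1ccc(CN2N=C(c3ccc(F)cc3)C3C=CC=CC3C2=O)cc1`, > 80000 nM
- compound 2 `CN(C)CCCCOC(=O)Nc1ccc(Cn2nc(-c3cncnc3)c3ccccc3c2=O)cc1`, 65300 nM
- compound 3 `CN(C)CCCCOC(=O)Nc1ccc(Cn2nc(-c3cnn(C)c3)c3ccccc3c2=O)cc1`, 55900 nM

The value of compound 1 is a limit of this assay, not a number (the limit of > 80000 nM in this assay, at which 1 of the 3 values shown sits). Among the two numbers, compound 3 has the lowest, and the step of a 1.2-fold lower number from compound 2 to compound 3 (0.07 log units; within the scatter) lies within the scatter, so compound 2 and compound 3 cannot be told apart.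

Compound 4 `CN(C)CCCCOC(=O)Nc1ccc(Cn2nc(-c3ccc(C#N)cc3)c3ccccc3c2=O)cc1` carries the change (4-cyanophenyl in place of 1-methyl-1H-pyrazol-4-yl on an aromatic carbon). Among the compounds with values here, the only measured step that bears on it, a 1.2-fold lower number from compound 2 to compound 3 (0.07 log units; within the scatter), exchanged one aromatic group for another at the same place and stayed within the scatter. On that basis no step beyond the scatter is expected in this assay; the step of a 1.1-fold lower number from compound 3 to compound 4 (0.05 log units; within the scatter) is the estimate. For compound 4 the expected value is 50000 nM, within 25000 nM to 90000 nM.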

Compound 4, half-maximal cytotoxic concentration: 37000 nM
Compound 4: the middle estimate sits 1.4-fold (0.13 log units) above what was measured; low and high end bracket the measured number.
By their numbers in this assay, from the lowest: compounds 4, 3 and 2 (each within the scatter of the next). At a limit, above all of these: compound 1.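

In this assay the step of a 1.5-fold lower number from compound 3 to compound 4 (0.18 log units; within the scatter) and the step of a 1.8-fold lower number from compound 2 to compound 4 (0.25 log units; within the scatter) show that this position also takes 4-cyanophenyl, a six-membered aromatic ring of carbon only, without a step beyond the scatter. Pyrimidin-5-yl, 1-methyl-1H-pyrazol-4-yl and 4-cyanophenyl therefore cannot be told apart here, whether the ring is five- or six-membered. Nothing measured here gives a reason for these steps. Open, from the compounds shown here alone, is how a non-aromatic group at this position, such as an amine or a longer chain, would read. Also open, going by these compounds, is a carboxylic acid in place of the nitrile.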